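The compounds below may be only part of what the source reports. "The series", "measured", "known", "first", "only" and "open" are said of these compounds alone.

Three compounds that share a core and differ only in the group on an amide-type nitrogen have been measured in an assay on isolated protein for inhibition of histone acetyltransferase p300 (Homo sapiens), with a stated time of 60 min; a lower number here means a stronger inhibitor, a higher number a weaker inhibitor. Compound 1 `O=C(Nc1ccc2[nH]c(=O)[nH]c2c1)[C@H]1CCCN1C(=O)C1(c2cccc(Cl)c2)CCCC1` gives 0.398 nM in this assay, compound 2 `O=C1Cc2cc(NC(=O)[C@H]3CCCN3C(=O)C3(c4cccc(Cl)c4)CCCC3)ccc2N1` gives 0.794 nM, and compound 3 `O=C(Nc1ccc2[nH]ncc2c1)[C@H]1CCCN1C(=O)C1(c2cccc(Cl)c2)CCCC1` gives 1 nM. Compound 3 therefore has the highest of the three numbers: a 1.3-fold higher number from compound 2 to compound 3 (0.10 log units; within the scatter), while a 2.5-fold higher number from compound 1 to compound 3 (0.40 log units; beyond the scatter), so only its distance from compound 1 reaches beyond the scatter.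

Compound 4 `CNC(=O)c1cccc(NC(=O)[C@H]2CCCN2C(=O)C2(c3cccc(Cl)c3)CCCC2)c1` is compound 3 with 3-(methylcarbamoyl)phenyl in place of 1H-indazol-5-yl on an amide-type nitrogen. The steps measured so far bear on this only loosely. They show that a 2.0-fold higher number from compound 1 to compound 2 (0.30 log units; within the scatter) when an aromatic bicyclic group is exchanged for a non-aromatic one, and that a 2.5-fold higher number from compound 1 to compound 3 (0.40 log units; beyond the scatter) when a carbonyl is lost from the bicyclic group; the step from compound 2 to compound 3 is the smallest of all. As far as these compounds go, none of them replaces the bicyclic group by a single six-membered aromatic ring, so the effect of the 3-(methylcarbamoyl)phenyl group is untested here. Given that every measured exchange at this position moved the number only a little, a modest step toward a higher number is expected, a 2.5-fold higher number from compound 3 to compound 4 (0.40 log units; beyond the scatter). Compound 4 is accordingly estimated at 2.5 nM in this assay, within a range from 0.7 nM to 9 nM.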

Compound 4, half-maximal inhibitory concentration in the histone acetyltransferase p300 assay: 1260 nM
For compound 4 the middle estimate is 500-fold (2.70 log units) below the measured one, and the stated range ends below it.
By their numbers in the histone acetyltransferase p300 assay, from the lowest: compounds 1, 2 and 3 (each within the scatter of the next, the first and the last beyond it); then compound 4.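

In the histone acetyltransferase p300 assay, the group on the amide-type nitrogen proves far less forgiving than the three bicyclic groups suggested: compound 4, with 3-(methylcarbamoyl)phenyl and its single six-membered aromatic ring of carbon only, gives 1260 nM, with a 1300-fold higher number from compound 3 to compound 4 (3.10 log units; beyond the scatter), a 1600-fold higher number from compound 2 to compound 4 (3.20 log units; beyond the scatter) and a 3200-fold higher number from compound 1 to compound 4 (3.50 log units; beyond the scatter). The group that leaves and the group that enters have equal counts of hydrogen-bond donors and acceptors, and in a physicochemical assay for lipophilicity, at pH 7.4 (a higher number here means a more lipophilic compound, a lower number a more polar compound), compound 3 gives 5.4 and compound 4 gives 5.5, with a number 0.10 log units higher from compound 3 to compound 4 (within the scatter), so neither the counts nor this read-out tells the two compounds apart. Nothing available here accounts for the size of the loss.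

The compounds shown leave open whether the large step follows from losing the five-membered aromatic ring or from the methylcarbamoyl group itself, as the two changes come together in compound 4. A plain phenyl group on the same amide-type nitrogen, or a phenyl group carrying a carboxylic acid or a simple amine instead of the methylcarbamoyl group, would begin to separate these two changes.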